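The source may hold more compounds than are shown below. What is called first, only, known or untested is meant among the compounds shown, and "the series" means these compounds.

Compound 1, `CO[C@H]1CC[C@H](NC(=O)c2n[nH]cc2NC(=O)c2cnc3ccccn23)CC1`, in an ADME assay on MRC5 cells (Homo sapiens) for inhibition, with a stated time of 72 h (a lower number here means that less compound is needed, a higher number that more compound is needed for the effect), gives 5900 nM. Compound 2, `COc1cccc(OC)c1C(=O)Nc1c[nH]nc1C(=O)Nc1ccncc1`, in this assay reaches only the limit of the assay, > 50000 nM. Compound 3, `CO[C@H]1CC[C@H](NC(=O)c2n[nH]cc2NC(=O)c2ccc(N3CCCC3)cc2)CC1`, in this assay likewise reaches only the limit, > 50000 nM.

Compound 2 thus stands at the edge of what this assay can report: its result is a limit and not a number, and the same is true of compound 3, so that compound 1 alone among the three carries a measured value. What the data show on this point, (the limit of > 50000 nM in this assay, at which 2 of the 3 values shown sit), says no more than that two of the three results sit at this limit.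

Compound 4, `COc1cccc(OC)c1C(=O)Nc1c[nH]nc1C(=O)NC1CCCCCC1`, differs from compound 2 in one place: cycloheptyl in place of pyridin-4-yl on an amide-type nitrogen. Going by the values given here, no step between measured compounds is on record for this change, so nothing shows which way it should move the result or by how much. Given that compound 2 already sits at the limit > 50000 nM, the expectation is that compound 4 will also be reported as a limit rather than as a number, and any step that the limit leaves unreadable from compound 2 to compound 4 is estimated to lie within the scatter. Compound 4 is therefore expected to give 60000 nM in this assay, between 15000 nM and 200000 nM.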

Compound 4, half-maximal effective concentration: 42000 nM
For compound 4 the middle estimate is 1.4-fold (0.15 log units) above the measured one; measured number inside the range.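

In this assay, cycloheptyl in place of pyridin-4-yl on an amide-type nitrogen brings an at least 1.1-fold lower number from compound 2 to compound 4 (0.07 log units; that floor lies within the scatter). Compound 4 gives a measured value, 42000 nM, so this place on the shared core can hold a group with which the result is a number and not a limit, something that compound 2 could not show. Because the result for compound 2 is a limit, the true size of this step stays unread, and the printed floor marks only its smallest possible size, so the change may be slight or much larger: the limit of > 50000 nM in this assay, at which 2 of the 4 values shown sit.

The compounds shown leave open whether the result follows from the seven-membered ring or from the loss of the aromatic ring with its nitrogen, a question that a cyclohexyl or a phenyl group on this same amide-type nitrogen would help to separate. They also leave open how an amine or a carboxylic acid carried on the cycloheptyl ring would move the number, and whether the same change would run the same way with another group on the other amide of the core.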